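The compounds below may be only part of what the source reports. "The series", "measured", "known", "first", "only" and "open" are said of these compounds alone.

Within the data shown here, in a functional assay on J774.A1 cells (Mus musculus) for inhibition, read by Griess assay, with stated times of 1 h and 24 h (a higher number here means a weaker inhibitor, a lower number a stronger inhibitor), compound 3 `CC(C)c1ccc(COc2ccccc2C2CC(=O)c3ccccc3O2)cc1` gives 28600 nM, and no measured step sets it apart beyond the scatter. Compound 1 `CC(C)CCOc1ccccc1C1CC(=O)c2ccccc2O1` gives 42600 nM there and compound 2 `CCCOc1ccccc1C1CC(=O)c2ccccc2O1` gives 44600 nM there. Compound 4 `CC(C)COc1ccccc1C1CC(=O)c2ccccc2O1` has isopropyl in place of 4-isopropylphenyl on a saturated chain carbon bound to an oxygen on an aromatic ring. Two steps exchange a group at that same carbon (a 1.5-fold lower number from compound 1 to compound 3 (0.17 log units; within the scatter)) and (a 1.6-fold lower number from compound 2 to compound 3 (0.19 log units; within the scatter)), and a third changes the chain further along (a 1.0-fold higher number from compound 1 to compound 2 (0.02 log units; within the scatter)). All three lie within the scatter. In this assay the expected step is accordingly none beyond the scatter (a 1.4-fold higher number from compound 3 to compound 4 (0.15 log units; within the scatter)). Compound 4 is estimated at 40000 nM as a middle value, with an expected range from 24000 nM up to 65000 nM as its upper end.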

Compound 4, half-maximal inhibitory concentration: 33200 nM
The estimate for compound 4 lay 1.2-fold (0.08 log units) above the measured number; the range from low to high includes it.
By their numbers in this assay, from the lowest: compounds 3, 4, 1 and 2 (each within the scatter of the next).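

In this assay, the loss of the aromatic ring at the saturated chain carbon bound to an oxygen on an aromatic ring, with 4-isopropylphenyl giving way to isopropyl, gives a 1.2-fold higher number from compound 3 to compound 4 (0.06 log units; within the scatter). Branching on the chain gives a 1.3-fold lower number from compound 2 to compound 4 (0.13 log units; within the scatter), and isopropyl in place of isobutyl gives a 1.3-fold lower number from compound 1 to compound 4 (0.11 log units; within the scatter), so a small branched group and a large aromatic one are not told apart at this position. No experimental evidence accompanies these results to explain them.

All four groups here contain only carbon, so an amine or a carboxylic acid on this chain remains an open case. Going by these compounds, whether any change at this position can give a step beyond the scatter also stays open.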